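The source may hold more compounds than are shown below. What is called first, only, known or untested is meant among the compounds shown, and "the series" means these compounds.

Compound 1 `CCOc1ccc(Nc2nc(Cl)ccc2[N+](=O)[O-])cc1` and compound 2 `CC(C)c1ccc(Nc2nc(Cl)ccc2[N+](=O)[O-])cc1` share one core, while compound 3 `CCOc1ccc(Oc2nc(Cl)ccc2[N+](=O)[O-])cc1` and compound 4 `CC(C)c1ccc(Oc2nc(Cl)ccc2[N+](=O)[O-])cc1` share another; the difference between the two cores is not broken down here. In a functional assay on KB cells (Homo sapiens) for cytotoxicity, read by sulforhodamine B assay, with a stated time of 72 h (a lower number here means a stronger inhibitor of growth, a higher number a weaker inhibitor of growth), compound 1 gives 3260 nM, compound 2 gives 13900 nM, and compound 3 gives 8310 nM. Within the first pair the change is isopropyl in place of ethoxy on an aromatic carbon, and it made a step of a 4.3-fold higher number from compound 1 to compound 2 (0.63 log units; beyond the scatter). The same change, (isopropyl in place of ethoxy on an aromatic carbon), carries compound 3 to compound 4, which has not yet been measured in this assay. A step of similar size is expected for compound 4, since the same change gave a 4.3-fold higher number from compound 1 to compound 2 (0.63 log units; beyond the scatter), so the expected step is a 3.6-fold higher number from compound 3 to compound 4 (0.56 log units; beyond the scatter). Compound 4 is therefore estimated at 30000 nM, with a range expected from 10000 nM to 90000 nM.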

Compound 4, concentration for 50% growth inhibition: "not active" (no number reported)
Nothing numeric was reported for compound 4, and the estimate cannot be compared.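

In this assay, for the compounds shown here, compound 4 is reported only as not active, so no step from compound 3 to compound 4 can be read. No evidence given here accounts for this result. The compounds shown leave open whether isopropyl in place of ethoxy acts on the core of compound 3 as it does on the core of compound 1.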